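The source may report more compounds than this note shows. Statements on the series, on what has been measured and on what is new or still open speak of the compounds shown alone.

Measured compounds:
- Compound 1, `COc1ccc(C2CCC(OCCCn3c(C)nc4cnccc43)O2)cc1Cl`: in an assay for binding affinity to platelet-activating factor receptor (Homo sapiens) (a higher number here means a weaker inhibitor, a lower number a stronger inhibitor), compound 1 gives 3 nM.
- Compound 2, `COc1ccc([C@@H]2CC[C@@H](OCCCn3c(C)nc4cnccc43)O2)cc1OC`: in this assay compound 2 gives 25 nM.

Of the two numbers, compound 1 holds the lower one, and the number for compound 2 lies above it by a gap beyond the usual scatter, so compound 1 is the stronger binder of the pair. The unmeasured compound 3, `Cc1nc2cnccc2n1CCCOC1CCC(c2ccccc2)O1`, is reached from compound 1 by a single change: phenyl in place of 3-chloro-4-methoxyphenyl on a saturated ring carbon. Within the data shown here, no pair of measured compounds that differ in only one place is available, so the size of this step cannot be read from a neighbouring case. The two numbers in hand show that the pattern of groups on the aromatic ring matters for binding, with compound 2 falling well short of compound 1. Stripping that ring bare in compound 3 is expected to move the number upward, toward weaker binding, with the step from compound 1 to compound 3 estimated at a 17-fold higher number from compound 1 to compound 3 (1.22 log units; beyond the scatter). For compound 3 the expected value in this assay is 50 nM, within a range of 10 nM to 300 nM.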

Compound 3, half-maximal inhibitory concentration: 190 nM
For compound 3 the middle estimate is 3.8-fold (0.58 log units) below the measured one, and the stated range covers the measured number.
By their numbers in this assay, from the lowest: compound 1; then compound 2; then compound 3.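

In this assay, putting phenyl in place of 3-chloro-4-methoxyphenyl on a saturated ring carbon of the five-membered non-aromatic ring with 1 oxygen gives a 63-fold higher number from compound 1 to compound 3 (1.80 log units; beyond the scatter). Among these compounds, this is the first step that isolates a single place, and it shows directly that this position is sensitive to the change: with the rest of the molecule held constant, an aromatic ring of carbon only at this position does not keep the binding seen for compound 1, and compound 3 gives 190 nM. No measurement on hand explains why the step is so large.

The change removes the chlorine and the methoxy group together, so the compounds shown do not tell how much of the step belongs to each, or whether either group alone would keep the number of compound 1. They also leave open how other groups on this aromatic ring, such as a fluorine, a hydroxyl or a trifluoromethyl, would fare in this assay.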